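Ring substituent swaps on the benzylamine of the shared core

The compounds below may be only part of what the source reports. "The series", "measured", "known", "first", "only" and "open" are said of these compounds alone.

For the measured compounds named here, compound 1 `Nc1nc(NCc2ccc(F)cc2)nc(-c2ccccc2CO)n1` stands lowest of the three measured members: in a functional assay on cells for positive allosteric modulation of G-protein coupled receptor 68 (Homo sapiens), read by a luciferase reporter and cAMP accumulation, with a stated time of 30 min, at pH 6.8 and pH 8.3, in the presence of a further agent that is not named here (on this read-out higher numbers stand for higher potency (the scale is a negative logarithm) and lower numbers for lower potency), compound 1 gives 3.97. Compound 2 `Nc1nc(NCc2cccc(Cl)c2)nc(-c2ccccc2CO)n1` gives 4.97 and compound 3 `Cc1cccc(CNc2nc(N)nc(-c3ccccc3CO)n2)c1` gives 4.4. Both differ from compound 1 only on the aryl ring of the benzylamine: a number 1.00 log units higher from compound 1 to compound 2 (beyond the scatter) with 3-chlorophenyl in place of 4-fluorophenyl on a saturated chain carbon bound to a nitrogen on an aromatic ring, and a number 0.43 log units higher from compound 1 to compound 3 (beyond the scatter) with 3-methylphenyl in place of 4-fluorophenyl at that carbon. Between those two, a number 0.57 log units lower from compound 2 to compound 3 (beyond the scatter), methyl in place of chloro on an aromatic carbon.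

Compound 4 `CC(C)Oc1ccc(CNc2nc(N)nc(-c3ccccc3CO)n2)cc1` differs from compound 1 as isopropoxy in place of fluoro on an aromatic carbon, on an aromatic carbon of a six-membered aromatic ring of carbon only, para to a large group. Going by the values given here, no measured step keeps the fluoro position and exchanges the group there; the two steps from compound 1 moved the substituent and raised the number, by a number 1.00 log units higher from compound 1 to compound 2 (beyond the scatter) and a number 0.43 log units higher from compound 1 to compound 3 (beyond the scatter). They bear only loosely on the present change, so the expectation rests on the series tolerating ring changes with gains. A modest rise of a number 0.53 log units higher from compound 1 to compound 4 (beyond the scatter) is expected in this assay. Compound 4 is accordingly estimated at 4.5, within 3.9 to 5.2.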

Compound 4, negative logarithm of the antagonist equilibrium constant: 4.99
Compound 4: middle estimate off by 0.49 log units, on the low side; the range from low to high includes it.
By their numbers in this assay, from the lowest: compound 1; then compound 3; then compounds 2 and 4 (each within the scatter of the next).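

In this assay, for the compounds shown here, isopropoxy in place of fluoro gives a number 1.02 log units higher from compound 1 to compound 4 (beyond the scatter) and is the first measured change that keeps the substituent para to a large group and exchanges only the group there. Raising the number therefore does not depend on moving the substituent from that place, as happened in a number 1.00 log units higher from compound 1 to compound 2 (beyond the scatter) and in a number 0.43 log units higher from compound 1 to compound 3 (beyond the scatter), and the place admits a group of 4 heavy atoms, including 1 hydrogen-bond acceptor, where fluoro has 1 heavy atom and none. Nothing available bears on why the number rises with this change.

The compounds shown leave open whether the rise goes with the ether oxygen or with the branched carbons, a question that methoxy, isopropyl or a longer alkoxy chain at that place would separate. Also open, as far as these compounds go, are the outcome with an amine or a carboxylic acid on that aromatic carbon, and the outcome with 3-isopropoxyphenyl in place of the 3-chlorophenyl of compound 2.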